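Sulfonyl aryl variation in a muscarinic M5 modulator series

The compounds below may be only part of what the source reports. "The series", "measured", "known", "first", "only" and "open" are said of these compounds alone.

Measured compounds:
compound 1 `CCN(C(=O)C1CCN(S(=O)(=O)c2ccc(OC)cc2)CC1)[C@H](C)c1ccccc1`: 90%
compound 2 `CCN(C(=O)C1CCN(S(=O)(=O)c2ccc3occc3c2)CC1)[C@H](C)c1ccccc1`: 80%
compound 3 `CCN(C(=O)C1CCN(S(=O)(=O)c2ccc3c(c2)CCC3)CC1)[C@H](C)c1ccccc1`: 97%

All three compounds share one core and differ only in the group on the sulfonyl sulfur; all were run in a functional assay on CHO cells for positive allosteric modulation of muscarinic acetylcholine receptor M5 (Homo sapiens), read by calcium flux; on this read-out lower numbers stand for smaller maximal responses and higher numbers for larger maximal responses. Compound 3 gives the highest of the three numbers, yet its gap to compound 1, a number 7 percentage points higher from compound 1 to compound 3 (within the scatter), is within the scatter, so no order between compound 3 and compound 1 is claimed. Compound 2 lies furthest away, a number 17 percentage points higher from compound 2 to compound 3 (beyond the scatter), beyond the scatter.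

Compound 4 `CCN(C(=O)C1CCN(S(=O)(=O)c2ccc3cn[nH]c3c2)CC1)[C@H](C)c1ccccc1` is not yet measured. Its change from compound 3: 1H-indazol-6-yl in place of 2,3-dihydro-1H-inden-5-yl on a sulfonyl sulfur

Among the compounds with values here, the step that bears most directly is the one from compound 2 to compound 3, a number 17 percentage points higher from compound 2 to compound 3 (beyond the scatter), where a fused five-membered ring holding a hetero atom was exchanged for a fused five-membered ring of carbon only and the number rose modestly; the step of a number 10 percentage points lower from compound 1 to compound 2 (within the scatter) points the same way but stays within the scatter. Compound 4 goes back toward a fused aromatic ring with hetero atoms, so a modest fall is expected in this assay, a number 15 percentage points lower from compound 3 to compound 4 (beyond the scatter), with no strong claim beyond the scatter. For compound 4 the estimate is 82%, expected to lie between 65% and 97%.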

Compound 4, largest response reached (reported as percent of maximum), in percent of the reference or control that the assay uses: 87%
For compound 4 the middle estimate is 5 percentage points below the measured one, within the range that was stated.
By their numbers in this assay, from the lowest: compounds 2, 4, 1 and 3 (each within the scatter of the next, the first and the last beyond it).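

In this assay, the 1H-indazol-6-yl group on the sulfonyl sulfur brings a five-membered aromatic ring with 2 hetero atoms, a hydrogen-bond donor and a hydrogen-bond acceptor, yet the steps (a number 10 percentage points lower from compound 3 to compound 4 (within the scatter)), (a number 7 percentage points higher from compound 2 to compound 4 (within the scatter)) and (a number 3 percentage points lower from compound 1 to compound 4 (within the scatter)) all stay within the scatter. The one gap beyond the scatter therefore remains that between compound 2 and compound 3, and compound 4 separates from neither, so a fused aromatic ring with hetero atoms does not, across these compounds, mark a group apart from the carbon-only fused ring of compound 3. Nothing available bears on the reason for this result.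

Still open, as far as these compounds go, is whether a 4-aminophenyl or 4-carboxyphenyl group on the sulfonyl sulfur would hold the largest response in this range. A saturated group such as cyclohexyl in the same place is equally open, as is any difference in potency, since only maximal responses are shown.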